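A few compounds are considered here, and "the series" means these few. Any claim that something is new, unique, unknown or untested is made for them only; others in the source may bear on it.

Working notes on the series.

The shared core of compound 1 is `Cc1nnc(Sc2cc(NC(=O)c3ccc(Cl)cc3)c3ccccc3c2O)s1`. In a functional assay on PC-3 cells (Homo sapiens) for antiproliferative activity, read by MTT assay, with a stated time of 48 h (on this read-out higher numbers stand for weaker inhibition and lower numbers for stronger inhibition), compound 1 gives 49500 nM, the highest of the two numbers recorded in this assay. Compound 2, `O=C(Nc1cc(Sc2ncn[nH]2)c(O)c2ccccc12)c1cccc([N+](=O)[O-])c1`, gives 26900 nM in this assay, and its gap to compound 1 lies within the scatter, so the two are not separated. Compound 3, `COc1ccc(/C=C/C(=O)Nc2cc(Sc3ncn[nH]3)c(O)c3ccccc23)cc1OC`, reaches only the limit > 100000 nM in this assay; this is the limit of > 100000 nM in this assay, at which 1 of the 3 values shown sits, and it is a limit rather than a number.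

Compound 4 is `Cn1nnnc1Sc1cc(NC(=O)c2ccc(Cl)cc2)c2ccccc2c1O`, not yet measured in this assay. It differs from compound 1 by 1-methyl-1H-tetrazol-5-yl in place of 5-methyl-1,3,4-thiadiazol-2-yl on a sulfur. Among the measured compounds shown here, no measured pair in this set changes this sulfur-bound ring, so no step of this kind has been seen, and the exchange of one five-membered heteroaromatic ring for another of the same size gives no grounds to expect a step beyond the scatter in either direction. The estimate for compound 4 in this assay is therefore 50000 nM, with a range from 20000 nM to 100000 nM, the expected step from compound 1 to compound 4 being a 1.0-fold higher number from compound 1 to compound 4 (0.00 log units; within the scatter).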

Compound 4, half-maximal inhibitory concentration: > 100000 nM
Compound 4: a limit, no number (the forecaster's own chance of this, stated with the estimate: 25%); middle value at least 2.0-fold (0.30 log units) away from the limit.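

Replacing 5-methyl-1,3,4-thiadiazol-2-yl with 1-methyl-1H-tetrazol-5-yl on a sulfur gives the first step seen at this position in this assay: an at least 2.0-fold higher number from compound 1 to compound 4 (0.30 log units; that floor lies within the scatter). The value of compound 4 is a limit and not a number, so this step is only a floor, and that floor does not clear the scatter. The change brings no measurable gain in inhibition, and a second compound now sits at the end of the read-out: the limit of > 100000 nM in this assay, at which 2 of the 4 values shown sit.

From the compounds shown here alone, it remains open whether any change of the sulfur-bound ring moves the read-out beyond the scatter, and how a carboxylic acid on a short chain would read in place of the ring. Also open, going by these compounds, is whether this exchange would read the same with the amide groups of compound 2 and compound 3.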